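The source may hold more compounds than are shown below. What is called first, only, known or untested is meant among the compounds shown, and "the series" means these compounds.

Measured in a functional assay on A2780 cells (Homo sapiens) for antiproliferative activity, read by MTT assay, with a stated time of 48 h; on this read-out higher numbers stand for weaker inhibition and lower numbers for stronger inhibition:
- compound 1 `COc1ccc(C(=O)c2ccc(OC)c3c2C=CC(C)(C)O3)c(NC(=O)CBr)c1`: 2150 nM
- compound 2 `COc1ccc(C(=O)c2ccc3c(c2)C=CC(C)(C)O3)c(NC(=O)CN)c1`: 590 nM
- compound 3 `COc1ccc(C(=O)c2ccc(OC)c3c2OC(C)(C)C=C3)c(NC(=O)CN(C)C)c1`: 790 nM

In this assay compound 2 gives 590 nM. This is within the scatter of compound 3 at 790 nM, while compound 1 at 2150 nM has a higher number, beyond the scatter. Compound 4 `COc1ccc(C(=O)c2ccc3c(c2)C=CC(C)(C)O3)c(NC(=O)CN(C)C)c1` departs from compound 2 by dimethylamino in place of amino on a saturated chain carbon bound to a carbonyl carbon, with dimethylamino in place of amino on a saturated chain carbon bound to a carbonyl carbon.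

Within the data shown here, no measured pair isolates this change. Among the measured compounds shown here, compound 3 also carries dimethylamino, but differs from compound 2 in other places too, and compound 3 at 790 nM gives the only indirect guide. No step beyond the scatter is therefore expected in this assay. The expected 1.2-fold higher number from compound 2 to compound 4 (0.07 log units; within the scatter) is small. Compound 4 is estimated at 700 nM, with an expected range of 280 nM to 1800 nM.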

Compound 4, half-maximal inhibitory concentration: 1020 nM
Compound 4: the middle estimate sits 1.5-fold (0.16 log units) below what was measured; the range from low to high includes it.
By their numbers in this assay, from the lowest: compounds 2, 3 and 4 (each within the scatter of the next); then compound 1.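

In this assay, among these compounds, the only direct reading of dimethylamino in place of amino on a saturated chain carbon bound to a carbonyl carbon is a 1.7-fold higher number from compound 2 to compound 4 (0.24 log units; within the scatter) on the shared core. The hydrogen-bond donor counted for amino is absent from dimethylamino, and the step stays within the scatter, so this donor is not shown to matter here. No measurement shown bears on the reason for this result.

As far as these compounds go, whether a piperidine or morpholine at this place, or a longer chain carrying the amine, would give a step beyond the scatter remains open.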